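This account rests on a few compounds, and the source may have more. Where it says the series, first, only, none or still open, it means among the compounds named here.

Measured so far:
- compound 1 `Cc1ccc([C@@H]2CC(c3cccc(O)c3)=NN2c2ccc(S(N)(=O)=O)cc2)cc1` — 64.7%
- compound 2 `NS(=O)(=O)c1ccc(N2N=C(c3cccc(O)c3)C[C@H]2/C=C/c2ccccc2)cc1` — 39.9%

Among the measured compounds shown here, compound 2 stands lowest of the two numbers so far, with compound 1 as its nearest neighbour at a number well above it. Both compounds were tested in a functional assay on the whole organism (strain Wistar albino) for inhibition, with Rattus norvegicus as the target, read by paw edema, with stated times of 30 min and 3 h, at a dose of 0.05 mmol/kg; on this read-out higher numbers stand for more inhibition at the one dose given (going by the name of the read-out) and lower numbers for less inhibition. For the measured compounds named here, the single measured step, a number 24.8 percentage points lower from compound 1 to compound 2 (beyond the scatter), came with the swap of a 4-methylphenyl for a 2-phenylethenyl on a saturated ring carbon of the shared core.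

Compound 3 `NS(=O)(=O)c1ccc(N2N=C(c3cccc(O)c3)C[C@H]2c2ccco2)cc1` has not been measured yet. It differs from compound 2 in one place: furan-2-yl in place of 2-phenylethenyl on a saturated ring carbon. This change undoes the 2-phenylethenyl that accompanied the drop from compound 1 to compound 2, and puts in its place a small aromatic ring, a situation closer to that of compound 1 than to that of compound 2. Going by the values given here, no step with a furan-2-yl at this position has been measured, so any expectation rests on the single step from compound 1 to compound 2 alone.

On that basis compound 3 is expected to recover part of the lost ground in this assay, with an expected step of a number 14.1 percentage points higher from compound 2 to compound 3 (beyond the scatter), likely beyond the scatter but not necessarily reaching the number of compound 1. The estimate for compound 3 is therefore 54%, within a range from 36% to 72%.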

Compound 3, a percentage reported as inhibition, in the whole organism at one dose (the size of the read-out at that dose, not a potency): 35.8%
Compound 3: the middle estimate sits 18.2 percentage points above what was measured; measured number below the stated range.
By their numbers in this assay, from the lowest: compounds 3 and 2 (each within the scatter of the next); then compound 1.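

In this assay, the swap of 2-phenylethenyl for furan-2-yl on this saturated ring carbon gives a number 4.1 percentage points lower from compound 2 to compound 3 (within the scatter), so this read-out does not separate these two quite different groups, one a longer unit ending in a six-membered ring and the other a five-membered aromatic ring with an oxygen. Replacing 4-methylphenyl with furan-2-yl gives a number 28.9 percentage points lower from compound 1 to compound 3 (beyond the scatter), so the earlier drop is no longer tied to 2-phenylethenyl alone: among these three compounds, the higher number belongs only to compound 1, the one carrying 4-methylphenyl. No measurement here explains why this group stands apart from the other two.

From the compounds shown here alone, it remains open whether the higher number of compound 1 goes with the six-membered aromatic ring itself or with the methyl group on that ring. A plain phenyl at this carbon would help to separate those two possibilities, and a 4-chlorophenyl or 4-methoxyphenyl would show whether other groups at that point on the ring give a similar number.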